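Amide in Place of the Acid on Compound 1

The compounds below may be only part of what the source reports. "The series", "measured", "known", "first", "only" and "open" are said of these compounds alone.

For the measured compounds named here, compound 1 `O=C(O)c1ccc2c(O)c(C(=O)O)cnc2c1` is one of two compounds measured in a functional assay on Ehrlich cells (Mus musculus) for inhibition (on this read-out lower numbers stand for stronger inhibition and higher numbers for weaker inhibition), where compound 1 gives 5750000 nM, the higher of the two numbers and so the weaker inhibitor. The other, compound 2 `CN(C)c1ccc2c(O)c(C(=O)O)cnc2c1`, gives 468000 nM. Going by the values given here, the one measured step, a 12-fold lower number from compound 1 to compound 2 (1.09 log units; beyond the scatter), shows that exchanging the carboxy group on the aromatic carbon for a different group can lower the number a great deal. Compound 3 `NC(=O)c1ccc2c(O)c(C(=O)O)cnc2c1` is not yet measured; it differs from compound 1 by amino in place of hydroxy on a carbonyl carbon. Among the compounds with values here, this change is smaller than the one leading to compound 2 and keeps the carbonyl, so only part of that step is expected to carry over. Compound 3 is therefore expected to show a 2.3-fold lower number from compound 1 to compound 3 (0.36 log units; beyond the scatter), an estimated 2500000 nM with a range from 700000 nM to 8000000 nM.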

Compound 3, half-maximal inhibitory concentration: 5750000 nM
For compound 3 the middle estimate is 2.3-fold (0.36 log units) below the measured one, and the stated range covers the measured number.
By their numbers in this assay, from the lowest: compound 2; then compounds 1 and 3 (each within the scatter of the next).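

Swapping hydroxy for amino on the carbonyl carbon gives no change at the digits printed from compound 1 to compound 3 (within the scatter) in this assay, so at this position the carboxy and carbamoyl groups cannot be told apart by this read-out. The step of a 12-fold higher number from compound 2 to compound 3 (1.09 log units; beyond the scatter) shows that the lower number seen earlier does not extend to every replacement for the carboxy group: among the three groups shown on this aromatic carbon, it goes with dimethylamino alone. Nothing measured here accounts for this difference between the groups.

Going by these compounds, it remains open whether the lower number belongs to dimethylamino specifically or would also appear with a primary amine or a diethylamino group on the same aromatic carbon. A methyl ester at this position would show whether other carbonyl groups also match the carboxy and carbamoyl groups.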